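Phenyl for Isobutyl on the Ring Carbon of Compound 3

A few compounds are considered here, and "the series" means these few. Any claim that something is new, unique, unknown or untested is made for them only; others in the source may bear on it.

Among the compounds with values here, compound 3 `Cc1ccc(S(=O)(=O)N2CCC(Cl)=CC2CC(C)C)cc1` is the one member of this small series with a measured number: in a functional assay on A2780 cells (Homo sapiens) for antiproliferative activity, read by sulforhodamine B assay, with a stated time of 48 h (on this read-out higher numbers stand for weaker inhibition of growth and lower numbers for stronger inhibition of growth), compound 3 gives 35000 nM. The other two compounds reach only an assay limit. Compound 1 `Cc1ccc(S(=O)(=O)N2CCC(Br)CC2)cc1` gives > 100000 nM in this assay, which is a limit rather than a number. Compound 2 `Cc1ccc(S(=O)(=O)N2CC[C@@H](Br)C[C@@H]2C2CCCCC2)cc1` likewise gives > 100000 nM in this assay, again a limit. Within the data shown here, compound 3 therefore stands as the only readable value, set against (the limit of > 100000 nM in this assay, at which 2 of the 3 values shown sit).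

Compound 4 `Cc1ccc(S(=O)(=O)N2CCC(Cl)=CC2c2ccccc2)cc1` differs from compound 3 by phenyl in place of isobutyl on a saturated ring carbon. Of the measured steps, only one is shown, a step that the two limits leave unreadable from compound 1 to compound 2, and both of its ends are limits, so its size cannot be read and it says nothing about the exchange of isobutyl for phenyl. Among the measured compounds shown here, no measured pair exchanges these two groups, so no step bears on the change from compound 3 to compound 4, and no direction can be taken from the data.

With nothing to point either way, compound 4 is expected to sit near compound 3, the step of a 1.4-fold lower number from compound 3 to compound 4 (0.15 log units; within the scatter) being estimated as small and within the scatter. Compound 4 is thus expected to give about 25000 nM in this assay, estimated between 6000 nM and 100000 nM.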

Compound 4, concentration for 50% growth inhibition: 17000 nM
Compound 4: middle estimate off by 1.5-fold (0.17 log units), on the high side; low and high end bracket the measured number.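

In this assay, the exchange of isobutyl for phenyl on this saturated ring carbon, next to the ring nitrogen, gives the series its first step that can be read, a 2.1-fold lower number from compound 3 to compound 4 (0.31 log units; beyond the scatter), and that step is modest. This position therefore carries a six-membered aromatic ring of carbon only without loss of growth inhibition, and the number moves to the lower side of that of the isobutyl compound. Compound 3 and compound 4 are now the only readable values, while compound 1 and compound 2 each remain at an assay limit: the limit of > 100000 nM in this assay, at which 2 of the 4 values shown sit.

From the compounds shown here alone, whether the step belongs to the aromatic ring itself or simply to the greater number of heavy atoms in phenyl stays open, and a cyclohexyl group on the core of compound 3 would separate the two. Also open, going by these compounds, is how far the number in this assay would move with an amine or a carboxylic acid on the phenyl ring, or with a longer chain at this ring carbon.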